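The compounds below may be only part of what the source reports. "The series", "measured", "known", "first", "only" and "open" are said of these compounds alone.

Compound 1 `CCOc1cccc(F)c1-c1cccc2nc(Nc3cc(OC)c(OC)c(OC)c3)oc12`: 490 nM
Compound 2 `COc1cc(Nc2nc3cccc(-c4c(F)cccc4OC(C)C)c3o2)cc(OC)c1OC`: 970 nM

In an assay on isolated protein for inhibition of ribosomal protein S6 kinase alpha-2 (Homo sapiens), with a stated time of 150 min (a lower number here means a stronger inhibitor, a higher number a weaker inhibitor), compound 1 gives 490 nM and compound 2 gives 970 nM. The step of a 2.0-fold higher number from compound 1 to compound 2 (0.30 log units; within the scatter) lies within the scatter, so the two compounds cannot be ranked against each other on these numbers. Compound 3 `COc1ccc(F)cc1-c1cccc2nc(Nc3cc(OC)c(OC)c(OC)c3)oc12` differs from compound 2 by a group of 9 heavy atoms (7 carbon, 1 oxygen, 1 fluorine; one six-membered aromatic ring of carbon only) in place of a group of 11 heavy atoms (9 carbon, 1 oxygen, 1 fluorine; one six-membered aromatic ring of carbon only), on an aromatic carbon, on an aromatic carbon ortho to a fused ring and meta to a fused ring. Among the measured compounds shown here, only one measured step touches the same aryl group, the one from compound 1 to compound 2, and it stayed within the scatter, which suggests that rearranging this aryl group does little in this assay. Compound 3 is therefore expected to land near compound 2, with a step of a 1.5-fold lower number from compound 2 to compound 3 (0.17 log units; within the scatter), not beyond the scatter. The estimate for compound 3 is 650 nM, with a range from 200 nM to 2000 nM.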

Compound 3, half-maximal inhibitory concentration: 40 nM
Compound 3: the middle estimate sits 16-fold (1.21 log units) above what was measured; measured number below the stated range.
By their numbers in this assay, from the lowest: compound 3; then compounds 1 and 2 (each within the scatter of the next).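

In this assay the aryl group on this aromatic carbon proves not to be indifferent: the 5-fluoro-2-methoxyphenyl group brings a 24-fold lower number from compound 2 to compound 3 (1.38 log units; beyond the scatter) and also a 12-fold lower number from compound 1 to compound 3 (1.09 log units; beyond the scatter), both beyond the scatter, whereas the earlier step between compound 1 and compound 2 could not be read. This gain comes with a change of the whole aryl group, in which both the place of the fluorine and the chain on the oxygen differ. Nothing measured here explains the gain.

The compounds shown leave open whether the place of the fluorine or the shorter methoxy chain carries the gain, which a 5-fluoro-2-ethoxyphenyl group would help to separate. They also leave open how an amine in place of that fluorine would read.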